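Working notes: isobutoxy to propoxy on the shared core

The source may hold more compounds than are shown below. What is called first, only, known or untested is meant among the compounds shown, and "the series" means these compounds.

- compound 1 `CCCC1=C(OCC(C)C)C(CCC)(CCC)C(=O)/C(=C(O)\C=C\c2ccccc2)C1=O`: 6.9 uM
- compound 2 `COC1=C(CC=C(C)C)C(=O)/C(=C(O)/C=C/c2ccccc2)C(=O)C1(CC=C(C)C)CC=C(C)C`: "not determined" (no result reported)
- compound 3 `CCCCC1=C(OC)C(CCCC)(CCCC)C(=O)/C(=C(O)\C=C\c2ccccc2)C1=O`: 5.9 uM

All entries come from a functional assay on 1A9 cells (Homo sapiens) for antiproliferative activity, read by sulforhodamine B assay, with a stated time of 3 days; on this read-out lower numbers stand for an effect already at smaller amounts and higher numbers for an effect only at larger amounts of compound. Among the compounds with values here, only two compounds carry a number, as compound 2 has no reported result. Compound 1, at 6.9 uM, holds the higher of these two numbers, but compound 3, at 5.9 uM, lies within the usual scatter of it, so the two cannot be ranked.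

The next compound to be measured is compound 4 `CCCOC1=C(CCC)C(=O)/C(=C(O)/C=C/c2ccccc2)C(=O)C1(CCC)CCC`. Its change from compound 1 is hydrogen in place of methyl on a saturated chain carbon bound to two saturated chain carbons, which reads as isobutoxy to propoxy when cut one bond further out.

Within the data shown here, no pair of measured compounds differs in one place only, so the series offers no direct precedent for this step. Among the measured compounds shown here, the one comparison available is the close agreement of compound 1 and compound 3, and it gives no sign of a large shift. No step beyond the scatter is expected in this assay, and no direction is favoured. The expected result is a 1.1-fold lower number from compound 1 to compound 4 (0.03 log units; within the scatter). For compound 4 the estimate is 6.5 uM, with an expected range of 3.3 uM to 13 uM.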

Compound 4, concentration for half-maximal effect: 2 uM
Compound 4: the middle estimate sits 3.3-fold (0.51 log units) above what was measured; measured number below the stated range.
By their numbers in this assay, from the lowest: compound 4; then compounds 3 and 1 (each within the scatter of the next).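

In this assay, within the data shown here, isobutoxy to propoxy on the shared core gives a 3.5-fold lower number from compound 1 to compound 4 (0.54 log units; beyond the scatter), the first step that can be read between compounds differing in one place. This position is therefore not silent: hydrogen in place of methyl on a saturated chain carbon bound to two saturated chain carbons is enough to carry the number beyond the scatter, although the step remains modest and the change involves no ring, no hydrogen-bond donor or acceptor and no net charge. Nothing measured in the material at hand accounts for this step.

With a single step at this position, the compounds shown cannot separate the loss of the branch from the shortening of the chain, so an unbranched butoxy chain and a shorter ethoxy group would be the informative comparisons on the core of compound 4. As far as these compounds go, it also remains open whether this position accepts something other than a plain alkyl chain, such as a benzyloxy group or a chain ending in an amine or a carboxylic acid.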